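Compound 3 to compound 4: methoxy removed from the aryl group

This account rests on a few compounds, and the source may have more. Where it says the series, first, only, none or still open, it means among the compounds named here.

In a functional assay on A549 cells (Homo sapiens) for cytotoxicity, read by MTT assay, with a stated time of 48 h (a lower number here means a stronger inhibitor, a higher number a weaker inhibitor), compound 1 `COc1ccc(OC)c(C2=NOC(COc3ccc(-c4nnnn4-c4cc(OC)c(OC)c(OC)c4)cc3N)C2)c1` gives 1930 nM, compound 2 `COc1ccc(-c2nnnn2-c2cc(OC)c(OC)c(OC)c2)cc1N` gives 2630 nM and compound 3 `COc1ccc(F)c(C2=NOC(COc3ccc(-c4nnnn4-c4cc(OC)c(OC)c(OC)c4)cc3N)C2)c1` gives 1510 nM. Compound 3 therefore stands within the scatter of both others. Compound 4 `COc1cc(-n2nnnc2-c2ccc(OCC3CC(c4ccccc4F)=NO3)c(N)c2)cc(OC)c1OC` differs from compound 3 by hydrogen in place of methoxy on an aromatic carbon, or 2-fluoro-5-methoxyphenyl to 2-fluorophenyl. Among the measured compounds shown here, only one measured step changes this aryl group: a 1.3-fold lower number from compound 1 to compound 3 (0.11 log units; within the scatter), with fluoro in place of methoxy on an aromatic carbon. For the measured compounds named here, no measured step shows the loss of a methoxy group without a replacement, so the evidence is indirect. No step beyond the scatter is expected in this assay. The expected step is a 1.1-fold higher number from compound 3 to compound 4 (0.05 log units; within the scatter). For compound 4 the estimate is 1700 nM, with an expected range of 700 nM to 4200 nM.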

Compound 4, half-maximal inhibitory concentration: 1490 nM
Compound 4: the middle estimate sits 1.1-fold (0.06 log units) above what was measured, within the range that was stated.
By their numbers in this assay, from the lowest: compounds 4, 3, 1 and 2 (each within the scatter of the next).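

In this assay, among the compounds shown here, removing the methoxy from the 2-fluoro-5-methoxyphenyl group with no replacement gives a 1.0-fold lower number from compound 3 to compound 4 (0.01 log units; within the scatter), the first direct reading of this position. Changing 2,5-dimethoxyphenyl to 2-fluorophenyl gives a 1.3-fold lower number from compound 1 to compound 4 (0.11 log units; within the scatter), and the group of 12 heavy atoms in place of a hydrogen atom gives a 1.8-fold lower number from compound 2 to compound 4 (0.25 log units; within the scatter), so all three steps lie within the scatter. From the compounds shown here alone, whether an amine or a carboxylic acid at this place, para to the fluoro group, would step beyond the scatter stays open. No supporting data offer an explanation for these readings.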